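This account rests on a few compounds, and the source may have more. Where it says the series, first, only, none or still open, it means among the compounds named here.

Measured in a functional assay on MiaPaCa cells (Homo sapiens) for antiproliferative activity, read by sulforhodamine B assay, with a stated time of 48 h; a lower number here means a stronger inhibitor of growth, a higher number a weaker inhibitor of growth:
Compound 1 `CCCCCc1ccc(-c2cn(CCCN3C(=O)COc4ccccc43)nn2)cc1`: > 100000 nM, a limit.
Compound 2 `COc1ccc2cc(-c3cn(CCCN4C(=O)COc5ccccc54)nn3)ccc2c1`: > 100000 nM, a limit.
Compound 3 `COc1ccc(-c2cn(CCCN3C(=O)COc4ccccc43)nn2)cc1`: 15700 nM.

For the measured compounds named here, compound 3 gives the only number in this set. What remains is the limit of > 100000 nM in this assay, at which 2 of the 3 values shown sit.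

Compound 4 `O=C1COc2ccccc2N1CCCn1cc(-c2cccnc2)nn1` differs from compound 3 in one place: pyridin-3-yl in place of 4-methoxyphenyl on an aromatic carbon. Going by the values given here, the one measured step that bears on this is an at least 6.3-fold lower number from compound 1 to compound 3 (0.80 log units; beyond the scatter), with methoxy in place of pentyl on an aromatic carbon. It shows that this assay can respond to a change in this part of the molecule, so a modest move towards weaker inhibition of growth is expected. The expected change is a 2.2-fold higher number from compound 3 to compound 4 (0.35 log units; beyond the scatter). For compound 4 the estimate is 35000 nM, with an expected range of 10000 nM to 100000 nM.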

Compound 4, concentration for 50% growth inhibition: 8200 nM
The estimate for compound 4 lay 4.3-fold (0.63 log units) above the measured number; measured number outside the range, below it.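

In this assay the change at this aromatic carbon gives a 1.9-fold lower number from compound 3 to compound 4 (0.28 log units; within the scatter) and so does not tell the two groups apart. The 4-methoxyphenyl group is therefore not needed to hold this level of growth inhibition, since pyridin-3-yl, with fewer heavy atoms, serves as well. Measured numbers still remain scarce in this set: the limit of > 100000 nM in this assay, at which 2 of the 4 values shown sit.

The compounds shown leave open how an amine or a carboxylic acid on this aromatic ring would read. They also leave open whether pyridin-4-yl would match pyridin-3-yl here.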